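The compounds below may be only part of what the source reports. "The series", "measured", "known", "first", "only" and "open" are said of these compounds alone.

Compound 1 `CCCCCCCC/N=C/N1CCC(C(c2ccccc2)c2ccccc2)CC1` gives 1.8 ug/mL in a functional assay (ileum) with Cavia porcellus as the target; on this read-out lower numbers stand for stronger inhibition and higher numbers for weaker inhibition. Among the compounds with values here, its only measured neighbour, compound 2 `CC(O)CCCCCC/N=C/N1CCC(C(c2ccccc2)c2ccccc2)CC1`, gives 1.7 ug/mL in this assay, and the step of a 1.1-fold lower number from compound 1 to compound 2 (0.02 log units; within the scatter) leaves the two side by side within the scatter. Compound 3 `O=C(O)CCCCCCC/N=C/N1CCC(C(c2ccccc2)c2ccccc2)CC1` has not yet been measured; it differs from compound 1 by carboxy in place of methyl on a saturated chain carbon, seven bonds along the chain from a double-bonded nitrogen. Within the data shown here, the one measured step swaps in a hydroxy rather than a carboxy, so it bears only loosely on this change, and it was flat. A modest weakening is nonetheless expected for compound 3, a 1.9-fold higher number from compound 1 to compound 3 (0.29 log units; within the scatter). Compound 3 is therefore estimated at 3.5 ug/mL, within 1.2 ug/mL to 12 ug/mL.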

Compound 3, half-maximal inhibitory concentration: 1.2 ug/mL
For compound 3 the middle estimate is 2.9-fold (0.46 log units) above the measured one; the measured number falls inside the stated range.
By their numbers in this assay, from the lowest: compounds 3, 2 and 1 (each within the scatter of the next).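

At this place, on a saturated chain carbon seven bonds along the chain from a double-bonded nitrogen, carboxy in place of methyl gives a 1.5-fold lower number from compound 1 to compound 3 (0.18 log units; within the scatter) in this assay, so even a group with a hydrogen-bond donor and acceptor leaves the read-out within the scatter. Carboxymethyl in place of 1-hydroxyethyl gives a 1.4-fold lower number from compound 2 to compound 3 (0.15 log units; within the scatter), so all three compounds lie within the scatter of one another. No evidence at hand accounts for this.

Going by these compounds, whether an amine, a methyl ester or a longer chain would also stay within the scatter remains open.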